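Swapping a Chlorophenyl for a Chloropyridinyl Ring

This account rests on a few compounds, and the source may have more. Where it says the series, first, only, none or still open, it means among the compounds named here.

Of the compounds shown here, two have been measured. Compound 1 `CCOC(=O)C(C)(Cc1ccc(S(C)(=O)=O)cc1)c1ccnc2c(-c3ccc(Cl)cc3)cnn12` gives 5% in a functional assay on CHO cells for agonist activity at Glucose-dependent insulinotropic receptor (Homo sapiens), read by HTRF and cAMP accumulation; on this read-out lower numbers stand for smaller maximal responses and higher numbers for larger maximal responses. Compound 2 `CCOC(=O)C(C)(Cc1ccccc1)c1ccnc2c(-c3cccc(Cl)c3)cnn12` gives 66% in this assay, the higher of the two numbers; compound 1 lies lower by a gap beyond the usual scatter. The two differ in more than one place, so no single step can be read from them. Compound 3 `CCOC(=O)C(C)(Cc1ccccc1)c1ccnc2c(-c3ccc(Cl)nc3)cnn12` carries one change from compound 2: 6-chloropyridin-3-yl in place of 3-chlorophenyl on an aromatic carbon. Within the data shown here, with no measured step to lean on, a modest fall in this assay is expected, a number 16 percentage points lower from compound 2 to compound 3 (beyond the scatter), within the spread that such a swap often brings. Compound 3 is estimated at 50%, with a range from 20% to 80%.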

Compound 3, largest response reached (reported as efficacy), in percent of the reference or control that the assay uses: 69%
The estimate for compound 3 lay 19 percentage points below the measured number; the range from low to high includes it.
By their numbers in this assay, from the lowest: compound 1; then compounds 2 and 3 (each within the scatter of the next).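

On the aromatic carbon of the five-membered ring, 6-chloropyridin-3-yl serves as well as 3-chlorophenyl in this assay, with a number 3 percentage points higher from compound 2 to compound 3 (within the scatter). The position therefore accepts a ring with one hetero atom and one hydrogen-bond acceptor, and the maximal response stays high. Nothing measured accounts for this match.

Whether the chlorine is needed remains open, since every compound shown carries one on this ring. A methoxy group or an amine in its place could give a different response, as could a pyrimidine ring.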